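Ring-closed amine in place of the open one

The source may hold more compounds than are shown below. What is called first, only, known or untested is meant among the compounds shown, and "the series" means these compounds.

Compound 1 `CCCCCCCCC[C@]1(c2ccccc2)OC[C@H]([C@@H]2CCCCN2)O1`, 43000 nM; compound 2 `C[C@H](N)[C@H]1COC(c2ccccc2)(c2ccccc2)O1`, 607 nM.

In a functional assay (brain) for displacement of a labelled ligand, with Rattus norvegicus as the target (on this read-out higher numbers stand for weaker inhibition and lower numbers for stronger inhibition), compound 2 gives 607 nM, the lowest of the two numbers, while compound 1 gives 43000 nM, a gap well beyond the scatter. Compound 3 `c1ccc(C2(c3ccccc3)OC[C@H]([C@@H]3CCCN3)O2)cc1` differs from compound 2 in one place: pyrrolidin-2-yl in place of 1-aminoethyl on a saturated ring carbon. Among the compounds with values here, no measured pair shows this kind of change, so compound 3 is expected to sit near compound 2, with a small shift toward a higher number; the expected step from compound 2 to compound 3 in this assay is a 1.6-fold higher number from compound 2 to compound 3 (0.22 log units; within the scatter). Compound 3 is estimated at 1000 nM, between 200 nM and 5000 nM.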

Compound 3, inhibition constant: > 10000 nM
Compound 3 gave a limit, no number (the forecaster's own chance of this, stated with the estimate: 5%); middle value at least 10-fold (1.00 log units) from the limit.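

In this assay compound 3 reads > 10000 nM, which is a limit of the assay and not a number. On this saturated ring carbon, pyrrolidin-2-yl in place of 1-aminoethyl gives an at least 16-fold higher number from compound 2 to compound 3 (1.21 log units; beyond the scatter), so this position does not freely accept the amine closed into a ring, which compound 1 and compound 2 alone could not show. The full size of this step cannot be read, since it rests on a limit: the limit of > 10000 nM in this assay, at which 1 of the 3 values shown sits.

On these data alone, whether the ring itself or only the larger group matters stays open. A 1-aminopropyl chain on the same carbon, an open amine with no ring, would bear on that.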